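Bromine in Place of Ethyl on the Anilino Ring

The compounds below may be only part of what the source reports. "The series", "measured", "known", "first", "only" and "open" are said of these compounds alone.

Compound 2 `CCc1ccc(NC2=CC(=O)c3nc4n(c3C2=O)[C@H]2OC[C@@H](O)[C@H]2OC4)cc1` carries a (4-ethylphenyl)amino group on the shared core, and in a functional assay on MCF7 cells (Homo sapiens) for inhibition, read by sulforhodamine B assay (a higher number here means a weaker inhibitor, a lower number a stronger inhibitor), compound 2 gives 960 nM. Among the two numbers shown, that of compound 2 is the lowest. Its nearest neighbour is compound 3 `COc1ccccc1NC1=CC(=O)c2c(nc3n2[C@H]2OC[C@@H](O)[C@H]2OC3)C1=O`, the 2-methoxyphenyl analogue, which in this assay gives 6580 nM, a gap beyond the usual scatter. Compound 1 `CCCc1ccc(NC2=CC(=O)c3c(nc4n3[C@H]3OC[C@@H](O)[C@H]3OC4)C2=O)cc1`, the 4-propylphenyl analogue, yields only a limit in this assay, namely > 4000 nM. The step from compound 1 to compound 3 a step that the limit leaves unreadable from compound 1 to compound 3 cannot be sized because of the limit of > 4000 nM in this assay, at which 1 of the 3 values shown sits.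

Compound 4 `O=C1C=C(Nc2ccc(Br)cc2)C(=O)c2c1nc1n2[C@H]2OC[C@@H](O)[C@H]2OC1` differs from compound 2 by bromo in place of ethyl on an aromatic carbon. Among the compounds with values here, no measured step covers an exchange of this kind, so the prediction rests on the closeness of compound 2 and compound 1 as para-substituted phenyl analogues and on the size of the group that enters. The estimate for compound 4 in this assay is 1400 nM, with an expected range from 450 nM to 4500 nM. The expected step from compound 2 to compound 4 is a 1.5-fold higher number from compound 2 to compound 4 (0.16 log units; within the scatter), a change not expected to exceed the scatter.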

Compound 4, half-maximal inhibitory concentration: 2580 nM
For compound 4 the middle estimate is 1.8-fold (0.27 log units) below the measured one; low and high end bracket the measured number.
By their numbers in this assay, from the lowest: compound 2; then compound 4; then compound 3.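

Bromo in place of ethyl on this aromatic carbon gives a 2.7-fold higher number from compound 2 to compound 4 (0.43 log units; beyond the scatter), the only step in this assay that can be read so far. Within the data shown here, it shows that this place, para to a large group, responds to the exchange of one substituent for another, whereas the earlier compounds offered no readable step there. A single bromine entering for the two carbons of ethyl, with neither group bringing a ring, a hydrogen-bond donor or acceptor, or a net charge, is enough to carry the number beyond the scatter.

Compound 1 gives only a limit, so the steps that involve it cannot be read: the limit of > 4000 nM in this assay, at which 1 of the 4 values shown sits. Going by these compounds, how chlorine, a hydroxyl group or an amine on the same aromatic carbon would read remains open.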